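A methyl group on the terminal phenyl of compound 1

The source may report more compounds than this note shows. Statements on the series, on what has been measured and on what is new or still open speak of the compounds shown alone.

Measured in a functional assay on HepG2 cells (Homo sapiens) for inhibition, read by fluorescence and resazurin assay, with a stated time of 72 h; a lower number here means a stronger inhibitor, a higher number a weaker inhibitor:
- compound 1 `O=C(Nc1ccccc1)Nc1cccc(Nc2nccc(Nc3ccc4cn[nH]c4c3)n2)c1` gives 8200 nM
- compound 2 `O=C(Nc1ccccc1)Nc1ccc(Nc2nccc(Nc3ccc4cn[nH]c4c3)n2)cc1` gives 11000 nM
- compound 3 `c1cc(Nc2ccc3cn[nH]c3c2)nc(Nc2ccc(Cn3cncn3)cc2)n1` gives 18000 nM

Compound 1 lies within the scatter of compound 2 , while compound 3 lies beyond the scatter of compound 1 . Compound 4 `Cc1cccc(NC(=O)Nc2cccc(Nc3nccc(Nc4ccc5cn[nH]c5c4)n3)c2)c1`, not yet measured, differs from compound 1 at one place. The difference turns phenylcarbamoyl into (3-methylphenyl)carbamoyl (methyl in place of hydrogen on an aromatic carbon).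

Among the measured compounds shown here, only one measured step is available, a 1.6-fold higher number from compound 2 to compound 3 (0.21 log units; within the scatter). It exchanges a whole group elsewhere on the molecule and stays within the scatter. For the measured compounds named here, no measured compound carries this methyl, so the data offer only weak guidance. In this assay, no change beyond the scatter is expected, and the estimated step is a 1.0-fold lower number from compound 1 to compound 4 (0.01 log units; within the scatter). For compound 4 the expected value is 8000 nM, within an estimated range from 3500 nM to 17000 nM.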

Compound 4, half-maximal inhibitory concentration: 2800 nM
Beside the measured number, compound 4's estimate is 2.9-fold (0.46 log units) above it; the whole stated range lies above it.
By their numbers in this assay, from the lowest: compound 4; then compounds 1, 2 and 3 (each within the scatter of the next, the first and the last beyond it).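

The earlier compounds shown here left the phenyl of the phenylcarbamoyl group unchanged, so they gave no reading of this ring; in this assay a single added methyl on an aromatic carbon, meta to a large group, gives a 2.9-fold lower number from compound 1 to compound 4 (0.47 log units; beyond the scatter), which shows that this ring is sensitive to a change of one heavy atom. The only other step shown, a 1.6-fold higher number from compound 2 to compound 3 (0.21 log units; within the scatter), exchanges a whole group yet stays within the scatter, so the size of a change does not by itself set the size of the step across these compounds. Nothing shown explains why this methyl lowers the number.

On these data alone, whether an ethyl group, a methoxy group or a chlorine atom on the same carbon would lower the number as well remains open. So does whether the same methyl would have a similar effect on compound 2 , which carries the same phenylcarbamoyl group.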